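The source may report more compounds than this note shows. Statements on the series, on what has been measured and on what is new or still open speak of the compounds shown alone.

Of the compounds shown here, three built on one shared core have been tested in a functional assay on L1210 cells (Mus musculus) for inhibition, read by thymidine incorporation, with a stated time of 3 h; a higher number here means that more compound is needed for the effect, a lower number that less compound is needed. Compound 1 `CC(C)CCCCCCCCCCCCC(=O)N[C@@H]1[C@@H](O)[C@H](O)[C@@H](Nc2ncnc3[nH]cnc23)O[C@H]1C` gives only a limit, > 1000 uM, so no number is known for it; this is the limit of > 1000 uM in this assay, at which 1 of the 3 values shown sits. Compound 2 `CCCCCCCCCCCC(=O)NCC(=O)N[C@@H]1[C@@H](O)[C@H](O)[C@@H](Nc2ncnc3[nH]cnc23)O[C@H]1C` gives 29 uM, and compound 3 `CCCCCCCCCCCCCCC(=O)NCCC(=O)N[C@@H]1[C@@H](O)[C@H](O)[C@@H](Nc2ncnc3[nH]cnc23)O[C@H]1CO` gives 100 uM. Of the two numbers, compound 2 stands at the lower one, while compound 3 sits at a higher number, and that gap is beyond the usual scatter of the assay. For the measured compounds named here, compound 2 and compound 3 differ in more than one place, so no single step between them can be read off.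

Compound 4 `CCCCCCCCCCCC(=O)NCC(=O)N[C@@H]1[C@@H](O)[C@H](O)[C@@H](Nc2ncnc3[nH]cnc23)O[C@H]1CO` has not yet been measured. It differs from compound 2 in one place: hydroxy in place of hydrogen on a saturated chain carbon bound to a saturated ring carbon. Compound 3 also carries a hydroxymethyl at that position, but with a different linker and a different acyl chain, so its value does not isolate this change. With no measured step of this kind among the compounds shown, the expectation is a small step, or none beyond the scatter. Compound 4 is expected to give 40 uM in this assay, estimated between 10 uM and 150 uM. The step of a 1.4-fold higher number from compound 2 to compound 4 (0.14 log units; within the scatter) is thus an estimate, not a measurement.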

Compound 4, concentration for half-maximal effect: 20 uM
The estimate for compound 4 lay 2.0-fold (0.30 log units) above the measured number; the range from low to high includes it.
By their numbers in this assay, from the lowest: compounds 4 and 2 (each within the scatter of the next); then compound 3. At a limit, above all of these: compound 1.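

In this assay, placing hydroxy in place of hydrogen on a saturated chain carbon bound to a saturated ring carbon, which is the same as turning methyl into hydroxymethyl, gives a 1.5-fold lower number from compound 2 to compound 4 (0.16 log units; within the scatter). For the compounds shown here, this is the first clean reading of this position, since compound 3 also carries the hydroxymethyl but differs from compound 2 in other places as well, so its value could not isolate the change. With the acyl chain and linker of compound 2 held fixed, methyl and hydroxymethyl cannot be told apart in this assay, and nothing shown offers a measured explanation for that result.

This single pair leaves open whether other groups at the same position, such as an aminomethyl or a carboxylic acid, would also leave the number unchanged. It also leaves open whether methyl and hydroxymethyl would remain indistinguishable on a compound with a longer acyl chain, since the change has been read on only one chain and one linker.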